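This account rests on a few compounds, and the source may have more. Where it says the series, first, only, none or still open, it means among the compounds named here.

Of the compounds shown here, two built on a shared core have been tested in a functional assay on PC-3 cells (Homo sapiens) for cytotoxicity, read by MTT assay, with a stated time of 48 h; a lower number here means a stronger inhibitor, a higher number a weaker inhibitor. Compound 1 `COc1cc(-c2nnc3n2NC(c2ccco2)C(C(=O)c2ccccc2)S3)cc(OC)c1OC` gives 64300 nM in this assay, the lower of the two numbers on record, although its gap to compound 2 lies within the usual scatter of repeated measurements, so the two cannot be ranked against each other. Compound 2 `COc1ccc(C(=O)C2Sc3nnc(-c4cc(OC)c(OC)c(OC)c4)n3NC2c2cccs2)cc1` gives 95900 nM in this assay. Compound 3 `COc1cc(-c2nnc3n2NC(c2ccco2)C(C(=O)c2ccc(-c4ccccc4)cc2)S3)cc(OC)c1OC` has not yet been measured. It differs from compound 1 in one place: phenyl in place of hydrogen on an aromatic carbon. For the measured compounds named here, no pair of measured compounds shows what such a change does, so the data give no direction for it. The expectation is that compound 3 comes out close to compound 1, with the step of a 1.1-fold lower number from compound 1 to compound 3 (0.03 log units; within the scatter) expected to stay within the scatter. Compound 3 is therefore estimated at 60000 nM in this assay, with a range from 25000 nM to 150000 nM.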

Compound 3, half-maximal inhibitory concentration: 45900 nM
Beside the measured number, compound 3's estimate is 1.3-fold (0.12 log units) above it; the measured number falls inside the stated range.
By their numbers in this assay, from the lowest: compounds 3, 1 and 2 (each within the scatter of the next, the first and the last beyond it).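

Placing phenyl on the aromatic carbon para to a large group, which turns phenyl into 4-phenylphenyl, gives a 1.4-fold lower number from compound 1 to compound 3 (0.15 log units; within the scatter) in this assay. For the compounds shown here, this is the first reading of this change, and it shows that a whole extra six-membered aromatic ring at this position leaves the number within the scatter, so the change cannot be called a gain or a loss. No other measurement bears on this outcome, so it stands as a plain observation.

As far as these compounds go, whether an amine, a carboxylic acid or a hexyl chain on the same carbon would move the number beyond the scatter remains open. Compound 2 differs from compound 1 in more than one place, so it gives no clean reading of this position.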